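Swapping methyl for fluoro on a pyridoimidazole oxime ether

This account rests on a few compounds, and the source may have more. Where it says the series, first, only, none or still open, it means among the compounds named here.

Measured compounds:
- compound 1, `COc1ccc(Cn2cc(CO/N=C/c3c(-c4ccc(C)cc4)nc4c(C)cccn34)nn2)cc1`, 100 mg/kg
- compound 2, `Cc1ccc(Cn2cc(CO/N=C/c3c(-c4ccc(F)cc4)nc4ccc(Br)cn34)nn2)cc1`, 100 mg/kg
- compound 3, `Cc1ccc(-c2nc3ccc(Br)cn3c2/C=N/OCc2cn(Cc3ccc(C#N)cc3)nn2)cc1`, 40 mg/kg

In a functional assay on the whole organism (strain NMRI) with Mus musculus as the target, with a stated time of 4 h (a higher number here means that more compound is needed for the effect, a lower number that less compound is needed), compound 1 gives 100 mg/kg, a value level with that of compound 2, and together these two are the highest of the three numbers; compound 3 needs a smaller dose, a difference beyond the usual scatter. Compound 4, `COc1ccc(Cn2cc(CO/N=C/c3c(-c4ccc(F)cc4)nc4c(C)cccn34)nn2)cc1`, differs from compound 1 by fluoro in place of methyl on an aromatic carbon. Among the compounds with values here, no pair of measured compounds differs by this single change, so the step must be judged from the whole set, in which compound 2 carries the same fluoro group yet gives the same dose as compound 1. The change from compound 1 to compound 4 is therefore expected to be no change at the digits printed from compound 1 to compound 4 (within the scatter), which is no step beyond the scatter. Compound 4 is estimated at 100 mg/kg, with a range from 40 mg/kg to 200 mg/kg.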

Compound 4, minimum effective dose: 40 mg/kg
The estimate for compound 4 lay 2.5-fold (0.40 log units) above the measured number, within the range that was stated.
By their numbers in this assay, from the lowest: compounds 3 and 4 (each within the scatter of the next); then compounds 1 and 2 (each within the scatter of the next).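

In this assay, replacing 4-methylphenyl with 4-fluorophenyl gives a 2.5-fold lower number from compound 1 to compound 4 (0.40 log units; beyond the scatter), a modest step but the first in this set that isolates a single change. It shows that the dose needed responds to the group at this one position, on the ring that carries it, with the rest of compound 1 left unchanged. No measurement shown here explains the step.

From the compounds shown here alone, whether a chloro, a methoxy or an amine at this position would lower the dose further remains open. So does whether the same swap would give a similar step on a compound with different groups elsewhere.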